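A few compounds are considered here, and "the series" means these few. Any claim that something is new, unique, unknown or untested is made for them only; others in the source may bear on it.

Two measured compounds share one core. Compound 1 `COc1cc(NC(=O)Nc2cc(Nc3cccc(C(C)(C)C)c3)ncn2)cc(OC)c1` carries a 3-(tert-butyl)phenyl group on a nitrogen on an aromatic ring. In a functional assay on HCC827 cells (Homo sapiens) for inhibition, read by MTT assay, with a stated time of 48 h, tested at 10 uM (a lower number here means less inhibition, a higher number more inhibition at the concentration tested (going by the name of the read-out)), compound 1 gives 48.7%, the highest of the two numbers recorded. Compound 2 `CC(C)(C)c1cccc(Nc2cc(NC(=O)Nc3c(Cl)cccc3Cl)ncn2)c1` differs from it only on the amide-type nitrogen, where 2,6-dichlorophenyl stands in place of 3,5-dimethoxyphenyl; in this assay compound 2 gives 37.3%, and that exchange produced a number 11.4 percentage points lower from compound 1 to compound 2 (beyond the scatter). Compound 3 `COc1cc(NC(=O)Nc2cc(Nc3cc(I)ccc3OC)ncn2)cc(OC)c1` has not yet been measured. It differs from compound 1 at a different place: 5-iodo-2-methoxyphenyl in place of 3-(tert-butyl)phenyl on a nitrogen on an aromatic ring. For the measured compounds named here, no measured step touches that nitrogen, so the only guide is that the single recorded change elsewhere on the shared core moved the read-out modestly. The account therefore expects a step of a number 6.7 percentage points lower from compound 1 to compound 3 (within the scatter), likely within the scatter or somewhat lower. The estimate for compound 3 is 42%, with a range from 20% to 65%.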

Compound 3, a percentage reported as inhibition, at one concentration (the size of the read-out at that concentration, not a potency): 71%
For compound 3 the middle estimate is 29 percentage points below the measured one; measured number above the stated range.
By their numbers in this assay, from the lowest: compound 2; then compound 1; then compound 3.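

The step on the nitrogen on an aromatic ring shows that this position can raise the read-out in this assay: with 3,5-dimethoxyphenyl kept on the amide-type nitrogen, 5-iodo-2-methoxyphenyl in place of 3-(tert-butyl)phenyl gives a number 22.3 percentage points higher from compound 1 to compound 3 (beyond the scatter). For the compounds shown here, the only earlier step, a number 11.4 percentage points lower from compound 1 to compound 2 (beyond the scatter), lay on the amide-type nitrogen and went down, so this is the first recorded change on the shared core to go up. Nothing on hand accounts for the rise.

The iodo and methoxy substituents enter together in compound 3, so the compounds shown do not separate their contributions to the step. As far as these compounds go, it also stays open whether the rise would persist with 2,6-dichlorophenyl on the amide-type nitrogen, or what an amine or a carboxylic acid on this aromatic ring would do to the read-out.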